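Swapping a triazole tail for a pyrrolidine on the shared core

A few compounds are considered here, and "the series" means these few. Any claim that something is new, unique, unknown or untested is made for them only; others in the source may bear on it.

Measured so far in a toxicity assay on L02 cells (Homo sapiens) for cytotoxicity, read by MTT assay, with a stated time of 72 h; a lower number here means a stronger inhibitor, a higher number a weaker inhibitor:
- compound 1, `O=C1c2c[n+]([O-])c3ccccc3c2C(=O)c2c1c1ccccc1n2Cc1cn(C[C@@H](O)CO)nn1`, 490 nM
- compound 2, `CC1(C)O[C@@H](CO)[C@H](Cn2cc(Cn3c4c(c5ccccc53)C(=O)c3c[n+]([O-])c5ccccc5c3C4=O)nn2)O1`, 500 nM
- compound 3, `O=C1c2c[n+]([O-])c3ccccc3c2C(=O)c2c1c1ccccc1n2Cc1cn([C@@H]2C[C@H](O)[C@@H](CO)O2)nn1`, 630 nM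

Compound 1 has the lowest of the three numbers in this assay, but its steps to the others are small: a 1.0-fold higher number from compound 1 to compound 2 (0.01 log units; within the scatter) and a 1.3-fold higher number from compound 1 to compound 3 (0.11 log units; within the scatter), and likewise a 1.3-fold higher number from compound 2 to compound 3 (0.10 log units; within the scatter). All three compounds keep the triazole on the saturated chain carbon bound to the aromatic nitrogen and differ only in what hangs from the triazole, so the measured steps show that such changes leave the number where it is.

Compound 4, `O=C1c2c[n+]([O-])c3ccccc3c2C(=O)c2c1c1ccccc1n2CCN1CCCC1`, is a different case: (pyrrolidin-1-yl)methyl in place of 1-(2,3-dihydroxypropyl)-1H-1,2,3-triazol-4-yl on a saturated chain carbon bound to an aromatic nitrogen. For the measured compounds named here, none of the measured steps removes the triazole, so nothing here bears directly on this change. Without a step to lean on, compound 4 is expected to sit near compound 1, with a wider range to allow for the larger change: a 1.1-fold lower number from compound 1 to compound 4 (0.04 log units; within the scatter), giving an estimated 450 nM, expected between 150 nM and 1400 nM.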

Compound 4, half-maximal inhibitory concentration: 930 nM
Beside the measured number, compound 4's estimate is 2.1-fold (0.32 log units) below it, within the range that was stated.
By their numbers in this assay, from the lowest: compounds 1, 2, 3 and 4 (each within the scatter of the next).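

In this assay, for the compounds shown here, the earlier compounds varied only what hangs from the triazole, whereas compound 4 replaces the triazole itself, and the result is a 1.9-fold higher number from compound 1 to compound 4 (0.28 log units; within the scatter). At this position, on a saturated chain carbon bound to an aromatic nitrogen, the number therefore stays within the scatter of compound 1 even when the aromatic ring, the defined stereocentre and the hydrogen-bond donors of 1-(2,3-dihydroxypropyl)-1H-1,2,3-triazol-4-yl all leave together. Nothing measured on these compounds accounts for this result.

The change swaps the ring and its link to the shared core in one move, so the compounds shown cannot separate the two contributions. Going by these compounds, it also remains open how an open-chain amine such as dimethylamino, a carboxylic acid or a longer chain carrying the pyrrolidine would read at this position.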